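The source may hold more compounds than are shown below. What is called first, only, known or untested is meant among the compounds shown, and "the series" means these compounds.

Measured so far in a functional assay on RAW264.7 cells (Mus musculus) for inhibition, read by Griess assay, with a stated time of 20 h (a higher number here means a weaker inhibitor, a lower number a stronger inhibitor), each value a limit and not a number:

Compound 1 `CCCNC(=O)c1ccc(-n2cc(-c3cccc(Cl)c3)nn2)cc1O`: > 20000 nM
Compound 2 `CC(C)CCc1cn(-c2ccc(C(=O)N3CCCCC3)c(O)c2)nn1`: > 20000 nM
Compound 3 `CCCCCCc1cn(-c2ccc(C(=O)N3CCCCC3)c(O)c2)nn1`: > 20000 nM

Compound 3 stands only at a limit, and it has company: the limit of > 20000 nM in this assay, at which 3 of the 3 values shown sit. Among the measured compounds shown here, the one measured step is a step that the two limits leave unreadable from compound 2 to compound 3, so it offers no size to carry forward. Compound 4 `O=C(c1ccc(-n2cc(-c3cccc(Cl)c3)nn2)cc1O)N1CCCCC1` differs from compound 3 in a single place: 3-chlorophenyl in place of hexyl on an aromatic carbon. Compound 1, which also carries 3-chlorophenyl, gives > 20000 nM, again a limit. With no readable step and no number on either side, no clear step in either direction is expected in this assay. The estimated step is a number no higher from compound 3 to compound 4 (the limit leaves the size open). Compound 4 is expected to give 20000 nM, with an estimated range of 7000 nM to 40000 nM.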

Compound 4, half-maximal inhibitory concentration: > 20000 nM
Compound 4: no number, only a limit; the forecaster's own chance of this, stated with the estimate: 70%; the middle value sits exactly at the limit.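

In this assay compound 4 gives > 20000 nM, a limit and not a number. The steps to compound 4 from compound 1, compound 2 and compound 3 therefore cannot be read: the limit of > 20000 nM in this assay, at which 4 of the 4 values shown sit.

The compounds shown leave open whether any of these changes alters inhibition at all.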